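This account rests on a few compounds, and the source may have more. Where it says the series, first, only, none or still open, it means among the compounds named here.

In a functional assay on the whole organism for inhibition, with Cavia porcellus as the target (a lower number here means that less compound is needed, a higher number that more compound is needed for the effect), compound 1 (`COc1ccccc1OCC1SCCN1C(=O)CN`) gives 57 mg/kg while compound 2 (`C=CC(=O)N1CCSC1COc1ccccc1OC`) gives 74 mg/kg and compound 3 (`COc1ccccc1OCC1SCCN1C(=O)CC(C)=O`) gives 30 mg/kg as its result. Two steps show where compound 3 stands (a 1.9-fold lower number from compound 1 to compound 3 (0.28 log units; within the scatter); a 2.5-fold lower number from compound 2 to compound 3 (0.39 log units; beyond the scatter)). Only the second lies beyond the scatter, and it is modest. The remaining step (a 1.3-fold higher number from compound 1 to compound 2 (0.11 log units; within the scatter)) also stays within the scatter.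

Compound 4 (`COc1ccccc1OCC1SCCN1C(=O)C(C)(C)C(=O)O`) keeps the shared core and differs only on the carbonyl carbon, with 1-carboxy-1-methylethyl in place of 2-oxopropyl (1-carboxy-1-methylethyl in place of 2-oxopropyl on a carbonyl carbon). For the measured compounds named here, no measured compound carries a carboxy group, so the three steps bear on this change only indirectly. Going by the values given here, they show that exchanging the group at this place has so far moved the number only slightly, and no step exceeds the modest one ending at compound 3. A small change is therefore expected, perhaps within the scatter, and more likely upward towards compound 2 with 74 mg/kg than downward. The expected step is a 1.5-fold higher number from compound 3 to compound 4 (0.18 log units; within the scatter) and this estimate remains loose. For compound 4 the estimated value is 45 mg/kg with an expected range (from 15 mg/kg to 130 mg/kg).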

Compound 4, dose for half-maximal effect: 34 mg/kg
For compound 4 the middle estimate is 1.3-fold (0.12 log units) above the measured one; the measured number falls inside the stated range.
By their numbers in this assay, from the lowest: compounds 3, 4, 1 and 2 (each within the scatter of the next, the first and the last beyond it).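

In this assay, 1-carboxy-1-methylethyl in place of 2-oxopropyl on the carbonyl carbon gives a step that stays within the scatter (a 1.1-fold higher number from compound 3 to compound 4 (0.05 log units; within the scatter)), so this position tolerates the first carboxy group seen here, and a larger group than 2-oxopropyl, without a clear change in the number. Compound 4 also repeats the contrast with the vinyl group seen for compound 3 (a 2.2-fold lower number from compound 2 to compound 4 (0.34 log units; beyond the scatter)), a modest step beyond the scatter, whereas the step from the aminomethyl group remains within it (a 1.7-fold lower number from compound 1 to compound 4 (0.22 log units; within the scatter)), so compound 1 does not separate from compound 4 as compound 2 does. Nothing measured on these compounds accounts for these small differences.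

The compounds shown leave open whether the unbranched carboxymethyl group or the methyl ester of the carboxylic acid would stay as close to compound 3 and compound 4 as these two stay to each other. They also leave open whether a longer chain or a phenyl group on the carbonyl carbon would move the number further than any step seen so far.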